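Swapping a pyrazole for a hydroxylated side chain

The compounds below may be only part of what the source reports. "The series", "measured", "known", "first", "only" and "open" are said of these compounds alone.

Among the compounds with values here, the three compounds measured so far share one core and differ in the group attached to the carbonyl of the amide. In an assay on cells for positive allosteric modulation of Cystic fibrosis transmembrane conductance regulator variant F508del (Homo sapiens), with stated times of 10 min and 7 s, in the presence of a further agent that is not named here (a lower number here means that less compound is needed, a higher number that more compound is needed for the effect), compound 1 `CC1(C)Cc2c(sc(NC(=O)c3ccccc3O)c2C(N)=O)CO1` gives 13 nM, compound 2 `CC1Cc2c(sc(NC(=O)c3ccccc3O)c2C(N)=O)C(C)O1` gives 4 nM, and compound 3 `CC1(C)Cc2c(sc(NC(=O)c3cn[nH]c3)c2C(N)=O)C(C)(C)O1` gives 125 nM. Compound 3 therefore stands at the highest number of the three, so the most compound is needed, and its gap to both compound 1 and compound 2 lies beyond the scatter.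

The next compound, compound 4 `CC1(C)Cc2c(sc(NC(=O)C(C)(C)O)c2C(N)=O)C(C)(C)O1`, keeps the core of compound 3 and changes only the group on the amide: 1-hydroxy-1-methylethyl in place of 1H-pyrazol-4-yl on a carbonyl carbon. Within the data shown here, no measured pair shows exactly this kind of exchange, so there is no step to lean on. The expectation is a small step, within the scatter, toward a higher number, a 1.6-fold higher number from compound 3 to compound 4 (0.20 log units; within the scatter). On that basis compound 4 is estimated at 200 nM in this assay, with a range from 50 nM to 800 nM.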

Compound 4, half-maximal effective concentration: 16 nM
The estimate for compound 4 lay 13-fold (1.10 log units) above the measured number, and the stated range ends above it.
By their numbers in this assay, from the lowest: compound 2; then compounds 1 and 4 (each within the scatter of the next); then compound 3.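

In this assay, the group on the carbonyl carbon of the amide clearly matters on this core: 1-hydroxy-1-methylethyl in place of 1H-pyrazol-4-yl gives a 7.8-fold lower number from compound 3 to compound 4 (0.89 log units; beyond the scatter), so an aromatic ring is not required at this position for a low number. The two groups carry the same count of hydrogen-bond donors and of hydrogen-bond acceptors, so those counts alone do not tell them apart. Nothing available here bears on the cause of this step.

The compounds shown leave open whether the step depends on the hydroxyl group or on the branched carbon chain that carries it. An amine in place of that hydroxyl, or a plain tert-butyl group on the same carbonyl carbon, would help separate the two.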